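The source may report more compounds than this note shows. Statements on the series, on what has been measured and on what is new or still open speak of the compounds shown alone.

Of the compounds shown here, three built on related cores have been tested in a functional assay on MCF7 cells (Homo sapiens) for antiproliferative activity, read by CCK-8 assay, with a stated time of 48 h; on this read-out lower numbers stand for stronger inhibition and higher numbers for weaker inhibition. Compound 1 `COc1ccc2[nH]c(C)c(C3=C(Cl)C(=O)C(c4c(-c5ccc(C)cc5)[nH]c5ccccc45)=C(Cl)C3=O)c2c1` gives 3.11 ug/mL in this assay. Compound 2 `Cc1ccc(-c2[nH]c3ccccc3c2C2=C(Cl)C(=O)C(c3c(C)[nH]c4ccccc34)=C(Cl)C2=O)cc1` differs from it by hydrogen in place of methoxy on an aromatic carbon, and in this assay compound 2 gives 2.8 ug/mL, so that the step is a 1.1-fold lower number from compound 1 to compound 2 (0.05 log units; within the scatter). Compound 3 `COc1ccc2[nH]c(C)c(C3=C(Br)C(=O)C(Br)=C(c4c(-c5ccccc5)[nH]c5ccccc45)C3=O)c2c1` has a different core; the difference between the two cores is not broken down here. In this assay compound 3 gives 3.38 ug/mL, which places it within the scatter of both compound 1 and compound 2.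

Compound 4 `Cc1[nH]c2ccccc2c1C1=C(Br)C(=O)C(Br)=C(c2c(-c3ccccc3)[nH]c3ccccc23)C1=O` has not yet been measured. It differs from compound 3 by hydrogen in place of methoxy on an aromatic carbon, the same change that leads from compound 1 to compound 2; among these compounds that change occurs twice in all. The earlier step was a 1.1-fold lower number from compound 1 to compound 2 (0.05 log units; within the scatter), which lay within the scatter. On that basis a similarly small step is expected, estimated as a 1.1-fold lower number from compound 3 to compound 4 (0.04 log units; within the scatter). Compound 4 is therefore expected to give about 3.1 ug/mL in this assay, most likely between 1.7 ug/mL and 5.6 ug/mL.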

Compound 4, half-maximal inhibitory concentration: 3.02 ug/mL
Estimate against measurement, compound 4: 1.0-fold (0.01 log units) above; the range from low to high includes it.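

In this assay, replacing the methoxy with hydrogen, so that 5-methoxy-2-methyl-1H-indol-3-yl becomes 2-methyl-1H-indol-3-yl, gives a 1.1-fold lower number from compound 3 to compound 4 (0.05 log units; within the scatter). Set beside the earlier case, the change behaves alike on the two cores: the same change on two cores in this assay, a 1.1-fold lower number (0.05 log units; within the scatter) from compound 1 to compound 2 and a 1.1-fold lower number (0.05 log units; within the scatter) from compound 3 to compound 4, 1.0-fold (0.00 log units) apart, within the scatter of two such steps This shows that in both pairs the methoxy can go without a change that stands out from the scatter, but since neither step is a measurable effect, it shows only that a near-absence of effect carries over, not that a real shift in potency would transfer from one core to another.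

The compounds shown leave open whether a different group at this place, such as an amine, a carboxylic acid or a longer chain like butoxy, would move the number beyond the scatter. Also open, on these data alone, is whether the step stays this small on any core beyond these two.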